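The source may hold more compounds than are shown below. What is called first, only, known or untested is meant among the compounds shown, and "the series" means these compounds.

Working notes on the series. Compound 3, `C[Si](C)(C)CCOCn1c(CC(O)CO)cc(=O)[nH]c1=O`, gives in a functional assay on MIA PaCa-2 cells (Homo sapiens) for antiproliferative activity, read by MTT assay, with a stated time of 72 h (a lower number here means a stronger inhibitor, a higher number a weaker inhibitor), only a limit and not a number, > 100000 nM. Compound 1, `C[Si](C)(C)CCOCn1c(CC(O)COCc2ccccc2)cc(=O)[nH]c1=O`, also gives only a limit in this assay, > 100000 nM. Compound 2, `Cc1c(CC(O)COCc2ccccc2)n(COCC[Si](C)(C)C)c(=O)[nH]c1=O`, likewise gives a limit in this assay, > 100000 nM. This is the limit of > 100000 nM in this assay, at which 3 of the 3 values shown sit. Two measured steps connect these compounds in this assay: a step that the two limits leave unreadable from compound 1 to compound 2, the same kind of change as the one now followed, and a step that the two limits leave unreadable from compound 1 to compound 3, the change that produces the diol side chain. Neither step can be sized, as both ends sit at the limit. Compound 4, `Cc1c(CC(O)CO)n(COCC[Si](C)(C)C)c(=O)[nH]c1=O`, differs from compound 3 by methyl in place of hydrogen on an aromatic carbon. Within the data shown here, the only step that bears on this change, a step that the two limits leave unreadable from compound 1 to compound 2, ran between two limits, so no direction and no size beyond the scatter can be read from it. Compound 4 is expected to remain at the limit in this assay, and the step that the limit leaves unreadable from compound 3 to compound 4 is expected to be unreadable. The estimate for compound 4 is 150000 nM, ranging from 50000 nM to 500000 nM.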

Compound 4, half-maximal inhibitory concentration: > 100000 nM
Compound 4 ended at the assay's limit (the forecaster's own chance of this, stated with the estimate: 90%); the middle value lies beyond the limit too.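

Neither new step, compound 3 to compound 4 or compound 2 to compound 4, can be read in this assay, and all values remain limits: the limit of > 100000 nM in this assay, at which 4 of the 4 values shown sit.

The compounds shown leave open the direction and size of either change, methyl in place of hydrogen or hydrogen in place of benzyl, in this assay.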